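Working notes: from compound 2 to compound 3

The source may hold more compounds than are shown below. What is called first, only, known or untested is meant among the compounds shown, and "the series" means these compounds.

Measured in a functional assay on A549 cells (Homo sapiens) for cytotoxicity, read by MTT assay, with a stated time of 48 h; a higher number here means a weaker inhibitor, a lower number a stronger inhibitor:
- compound 1 `COc1cc(/C=C2\C(=O)Nc3ccc(Cl)cc32)ccc1OCCCN1CCN(c2ccccn2)CC1`: > 20000 nM, a limit of the assay and not a number
- compound 2 `COc1cc(/C=C2\C(=O)Nc3ccc(Cl)cc32)ccc1OCCCN1CCN(c2ncccc2C(F)(F)F)CC1`: 9530 nM

Going by the values given here, compound 2, at 9530 nM, holds the only actual number so far, so it has no second number to be ranked against.

Compound 3 `COc1cc(/C=C2\C(=O)Nc3ccc(Cl)cc32)ccc1OCCCN1CCN(C)CC1` is not yet measured. The change is methyl in place of 3-(trifluoromethyl)pyridin-2-yl on an amine nitrogen in a ring.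

Among the compounds with values here, the only measured step that bears on this is an at least 2.0-fold lower number from compound 1 to compound 2 (0.32 log units; beyond the scatter), with trifluoromethyl in place of hydrogen on an aromatic carbon. Compound 3 also lacks that trifluoromethyl, so this step is read in reverse as a weak guide. Within the data shown here, no measured step covers loss of the whole aromatic group, which leaves the expectation wide.

A modest move to a higher number in this assay is expected, and the assay may well report only a limit. The expected change is a 2.1-fold higher number from compound 2 to compound 3 (0.32 log units; beyond the scatter). For compound 3 the estimated value is 20000 nM, with an expected range of 8000 nM to 50000 nM.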

Compound 3, half-maximal inhibitory concentration: 11300 nM
For compound 3 the middle estimate is 1.8-fold (0.25 log units) above the measured one; low and high end bracket the measured number.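

In this assay, the step at this position is large in structure but not in read-out: with methyl in place of 3-(trifluoromethyl)pyridin-2-yl on the amine nitrogen in a ring, the series shows a 1.2-fold higher number from compound 2 to compound 3 (0.07 log units; within the scatter). Compound 2 and compound 3 therefore cannot be told apart, and the aromatic ring with its trifluoromethyl is not required to reach this level of cytotoxicity in these two compounds. Against compound 1, the series shows an at least 1.7-fold lower number from compound 1 to compound 3 (0.24 log units; that floor lies within the scatter), and this floor does not by itself establish a real gap; the value of compound 1 is a limit of the assay and not a number, so how far it really lies from the other two stays unknown: the limit of > 20000 nM in this assay, at which 1 of the 3 values shown sits.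

The three compounds leave open whether any group on this nitrogen moves the number well away from the level of compound 2 and compound 3, since a hydrogen, a longer chain such as hydroxyethyl, or a carboxylic acid on an alkyl chain does not appear among them. They also leave open whether the flat result holds with another substituent on the shared core.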